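This account rests on a few compounds, and the source may have more. Where it says the series, first, only, none or still open, it means among the compounds named here.

Measured in a functional assay on HCT-116 cells (Homo sapiens) for inhibition; on this read-out higher numbers stand for an effect only at larger amounts of compound and lower numbers for an effect already at smaller amounts:
- compound 1 `COc1cc(N2CCN(C(=O)N3CCN(C)CC3)CC2)ccc1Nc1nc(NC2CCCCC2)c2nc[nH]c2n1`: 18 nM
- compound 2 `COc1cc(N2CCN(Cc3ccccn3)CC2)ccc1Nc1nc(NC2CCCCC2)c2nc[nH]c2n1`: 89 nM

Compound 2, at 89 nM, holds the higher of the two numbers. Compound 3 `COc1cc(N2CCN(C(=O)N3CCC(O)C3)CC2)ccc1Nc1nc(NC2CCCCC2)c2nc[nH]c2n1` departs from it by one change, with (3-hydroxypyrrolidin-1-yl)carbonyl in place of (pyridin-2-yl)methyl on an amine nitrogen in a ring.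

Among the compounds with values here, only one measured step bears on this: a 4.9-fold higher number from compound 1 to compound 2 (0.69 log units; beyond the scatter). It is modest but beyond the scatter, and it removed (4-methylpiperazin-1-yl)carbonyl in favour of (pyridin-2-yl)methyl. Compound 1, at 18 nM, has a carbonyl at this place, as compound 3 will, although the ring on that carbonyl differs. Within the data shown here, no measured compound carries the entering group, so only a cautious reversal is expected in this assay, towards a lower number and of similar or somewhat smaller size. The expected step is a 3.2-fold lower number from compound 2 to compound 3 (0.50 log units; beyond the scatter). Compound 3 is estimated at 28 nM, with an expected range of 9 nM to 85 nM.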

Compound 3, half-maximal effective concentration: 100 nM
Beside the measured number, compound 3's estimate is 3.6-fold (0.55 log units) below it, and the stated range ends below it.
By their numbers in this assay, from the lowest: compound 1; then compounds 2 and 3 (each within the scatter of the next).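

In this assay, a carbonyl on this amine nitrogen is not enough to reach the number of compound 1: the step of a 1.1-fold higher number from compound 2 to compound 3 (0.05 log units; within the scatter) shows that (3-hydroxypyrrolidin-1-yl)carbonyl and (pyridin-2-yl)methyl cannot be told apart here, even though they differ in ring, donors and acceptors. With the carbonyl held in place, the group on it does make a difference: the step of a 5.6-fold higher number from compound 1 to compound 3 (0.74 log units; beyond the scatter) comes with 3-hydroxypyrrolidin-1-yl in place of 4-methylpiperazin-1-yl on a carbonyl carbon. No supporting data are available to explain either result.

The compounds shown leave open which part of 4-methylpiperazin-1-yl goes with the lower number, the six-membered ring or its second nitrogen with the methyl group. A piperidin-1-yl or an unsubstituted piperazin-1-yl on the same carbonyl would separate these, and a plain pyrrolidin-1-yl would test the hydroxyl.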